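The source may report more compounds than this note shows. Statements on the series, on what has been measured and on what is new or still open speak of the compounds shown alone.

Of the compounds shown here, three have been tested so far in an ADME assay on HT-29 cells (Homo sapiens) for cytotoxicity, read by MTT assay, with a stated time of 72 h; on this read-out higher numbers stand for weaker inhibition and lower numbers for stronger inhibition. Compound 1 `COc1cc(C2=C(c3cc(C)c(OC)c(C)c3)C(O)CC2=O)cc(OC)c1OC` gives > 100 ug/mL, which is a limit of the assay and not a number. Compound 2 `COc1ccc(C2=C(c3cc(OC)c(OC)c(OC)c3)CC(O)C2=O)cc1[N+](=O)[O-]` gives > 100 ug/mL, also a limit. Compound 3 `COc1ccc(C2=C(c3cc(OC)c(OC)c(OC)c3)C(=O)CC2O[SiH2]C(C)(C)C)cc1OC`, which carries a silicon-bearing group, gives > 100 ug/mL, again a limit. Compound 2 therefore stands with the others at the limit of > 100 ug/mL in this assay, at which 3 of the 3 values shown sit, and no exact number is known for it. Compound 4 `COc1ccc(C2=C(c3cc(OC)c(OC)c(OC)c3)CC(O[SiH2]C(C)(C)C)C2=O)cc1[N+](=O)[O-]` is compound 2 with one structural change, (a group of 5 heavy atoms (4 carbon, 1 silicon; no ring) in place of a hydrogen atom, on an oxygen on a saturated carbon), a group with no ring placed on an oxygen on a saturated carbon. For the measured compounds named here, no measured pair shows this change alone, but the silicon-bearing compound 3 reached only the limit, so little movement is expected. The expected a number no higher from compound 2 to compound 4 (the limit leaves the size open) is small, leaning slightly toward stronger inhibition, and may not exceed the usual scatter. For compound 4 the estimated value is 100 ug/mL, with an expected range from 30 ug/mL to 150 ug/mL.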

Compound 4, half-maximal inhibitory concentration: > 100 ug/mL
Compound 4: no number, only a limit; the forecaster's own chance of this, stated with the estimate: 65%; the middle value sits exactly at the limit.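

For the compounds shown here, compound 2 and compound 4 both give only a limit and not a number, so no step between them can be read in this assay. What any structural change among these compounds does to the read-out stays open: the limit of > 100 ug/mL in this assay, at which 4 of the 4 values shown sit.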